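From Chloro to Nitro on an Aromatic Carbon

The compounds below may be only part of what the source reports. "The series", "measured", "known", "first", "only" and "open" are said of these compounds alone.

Compound 1 `Cc1ccc(/C=C2/S/C(=N/c3ccccc3)N(Cc3ccncc3)C2=O)cc1`: 49500 nM
Compound 2 `O=C1/C(=C\c2ccc(Cl)cc2)S/C(=N/c2ccccc2)N1Cc1ccncc1`: 42300 nM

In an ADME assay on HEK293 cells (Homo sapiens) for cytotoxicity, read by MTT assay, with a stated time of 48 h (a higher number here means a weaker inhibitor, a lower number a stronger inhibitor), compound 2 gives 42300 nM, which lies within the scatter of compound 1 at 49500 nM. Compound 3 `O=C1/C(=C\c2ccc([N+](=O)[O-])cc2)S/C(=N/c2ccccc2)N1Cc1ccncc1` carries nitro in place of chloro on an aromatic carbon, para to a large group: nitro in place of chloro on an aromatic carbon. Going by the values given here, the only measured step that bears on this change, a 1.2-fold lower number from compound 1 to compound 2 (0.07 log units; within the scatter), replaced methyl with chloro on an aromatic carbon and stayed within the scatter. The expected change is therefore a 1.1-fold lower number from compound 2 to compound 3 (0.02 log units; within the scatter), with nothing beyond the scatter foreseen in this assay. For compound 3 the estimated value is 40000 nM, with an expected range of 20000 nM to 80000 nM.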

Compound 3, half-maximal inhibitory concentration: 250000 nM
For compound 3 the middle estimate is 6.3-fold (0.80 log units) below the measured one; measured number above the stated range.
By their numbers in this assay, from the lowest: compounds 2 and 1 (each within the scatter of the next); then compound 3.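

The aromatic carbon para to a large group is not indifferent to every group: methyl and chloro stayed within the scatter of each other, but in this assay nitro gives the weakest inhibitor of the three (a 5.9-fold higher number from compound 2 to compound 3 (0.77 log units; beyond the scatter)) and (a 5.1-fold higher number from compound 1 to compound 3 (0.70 log units; beyond the scatter)). Nothing given here accounts for this shift. Going by these compounds alone, with only three groups at this place, it remains open whether an amine or a carboxylic acid would stay with methyl and chloro or move the number as nitro does. On these data alone, it is also open whether nitro has the same effect when another part of the shared core changes.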